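The source may hold more compounds than are shown below. What is called first, only, known or untested is meant among the compounds shown, and "the series" means these compounds.

In an ADME assay on MT4 cells (Homo sapiens) for cytotoxicity, read by MTT assay (a higher number here means that more compound is tolerated, a lower number that less compound is tolerated), compound 1 (`O=C(CSc1nncnc1-c1ccccc1Cl)Nc1ccccc1`) gives 127000 nM, compound 2 (`CC(=O)c1ccc(NC(=O)CSc2nncnc2-c2ccccc2Cl)c(Br)c1`) gives 34000 nM and compound 3 (`CC(=O)c1ccc(NC(=O)CSc2nncnc2-c2cccc3ccccc23)c(Br)c1`) gives 133000 nM. Compound 3 therefore stands level with compound 1, within the scatter, and well clear of compound 2. The next compound, compound 4 (`O=C(CSc1nncnc1-c1cccc2ccccc12)Nc1ccccc1F`), has 2-fluorophenyl in place of 4-acetyl-2-bromophenyl on an amide-type nitrogen. Going by the values given here, the one measured step, a 3.9-fold higher number from compound 2 to compound 3 (0.59 log units; beyond the scatter), is a modest one, but it concerns the other aromatic group and not this nitrogen. Among the compounds with values here, no measured step covers the exchange itself. The closest guide is the pair of compound 1 and compound 2, which differ at that nitrogen and whose two values are shown above. Compound 4 loses the 4-acetyl-2-bromophenyl group, yet compound 3 carries that group and already reaches 133000 nM, so no step beyond the scatter is expected. The expected change is a 1.1-fold higher number from compound 3 to compound 4 (0.02 log units; within the scatter). Compound 4 is estimated at 140000 nM, with an expected range of 60000 nM to 300000 nM.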

Compound 4, half-maximal cytotoxic concentration: 65000 nM
Compound 4: middle estimate off by 2.2-fold (0.33 log units), on the high side; the measured number falls inside the stated range.
By their numbers in this assay, from the lowest: compounds 2, 4, 1 and 3 (each within the scatter of the next, the first and the last beyond it).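

Measured directly on the amide-type nitrogen, the exchange of 4-acetyl-2-bromophenyl for 2-fluorophenyl gives a 2.0-fold lower number from compound 3 to compound 4 (0.31 log units; beyond the scatter) in this assay and so shows that this position does affect the tolerated concentration when naphthalen-1-yl is present. The group does not go with the lower number everywhere: with 2-chlorophenyl on the shared core, compound 1, with phenyl on the nitrogen, gives 127000 nM and compound 2, with 4-acetyl-2-bromophenyl, gives 34000 nM while compound 3, which carries that group, stands above compound 4. Nothing available explains this difference in direction.

The compounds shown leave open whether the acetyl, the bromine or the fluorine accounts for the step. They also leave open how a morpholine or a carboxylic acid on this aromatic ring, or a cyclohexyl group in its place, would read.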